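The source may hold more compounds than are shown below. What is called first, only, known or untested is meant among the compounds shown, and "the series" means these compounds.

Of the compounds shown here, three sharing one core have been measured in a functional assay on CHO cells for agonist activity at prostaglandin E2 receptor EP3 subtype (Homo sapiens), read by fluorescence and calcium flux; on this read-out lower numbers stand for an effect already at smaller amounts and higher numbers for an effect only at larger amounts of compound. Compound 1 `O=C(O)CC[C@@H]1CC[C@@H]2[C@@H](/C=C/[C@@H](O)COc3ccccc3)[C@H](O)C[C@@H]2OC1` gives 870 nM. Compound 2 `O=C(O)CCC[C@@H]1CC[C@@H]2[C@@H](/C=C/[C@@H](O)COc3ccccc3)[C@H](O)C[C@@H]2OC1` gives 2.3 nM, and compound 3 `O=C(O)CCC[C@H]1CC[C@@H]2[C@@H](/C=C/[C@@H](O)COc3ccccc3)[C@H](O)C[C@@H]2OC1` gives 4 nM. Compound 2 thus has the lowest number of the three, though its step to compound 3, a 1.7-fold higher number from compound 2 to compound 3 (0.24 log units; within the scatter), lies within the scatter, so the two cannot be ranked against each other; this rests on (the fact that compounds 2 and 3 differ only in the configuration as drawn). The step of a 380-fold lower number from compound 1 to compound 2 (2.58 log units; beyond the scatter) is the only large one.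

Compound 4 `O=C(O)CCCC[C@@H]1CC[C@@H]2[C@@H](/C=C/[C@@H](O)COc3ccccc3)[C@H](O)C[C@@H]2OC1` is the next member. Compared with compound 2 the change is carboxymethyl in place of carboxy on a saturated chain carbon, three bonds along the chain from a saturated ring carbon. This is the same kind of lengthening that separates compound 1 from compound 2, cut one bond further out. Among the measured compounds shown here, that earlier lengthening brought a large fall in the number, but no measured step shows what a second lengthening does, and compound 2 already stands at the bottom of the measured range. A further large fall therefore seems unlikely; a modest rise, possibly within the scatter, is the more cautious expectation. Compound 4 is expected to give 10 nM, in a range from 2 nM to 60 nM, which corresponds to an estimated step of a 4.3-fold higher number from compound 2 to compound 4 (0.64 log units; beyond the scatter).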

Compound 4, half-maximal effective concentration: 130 nM
For compound 4 the middle estimate is 13-fold (1.11 log units) below the measured one, and the stated range ends below it.
By their numbers in this assay, from the lowest: compounds 2 and 3 (each within the scatter of the next); then compound 4; then compound 1.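

The change of carboxymethyl in place of carboxy does not act the same way each time it is made on this chain: after a 380-fold lower number from compound 1 to compound 2 (2.58 log units; beyond the scatter), the same change cut one bond further out brings a 57-fold higher number from compound 2 to compound 4 (1.75 log units; beyond the scatter). The 4-carboxybutyl chain does not lose all that the 3-carboxypropyl chain gained, since the comparison with the 2-carboxyethyl chain still shows a 6.7-fold lower number from compound 1 to compound 4 (0.83 log units; beyond the scatter). In this assay, the number therefore follows no one-way trend with chain length: among compounds 1, 2 and 4, which share one configuration as drawn, the 3-carboxypropyl chain of compound 2 gives the lowest number, and both the shorter and the longer chain give higher ones.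

Still open, on these data alone, is whether a longer chain such as 5-carboxypentyl, or a tetrazole in place of the carboxy group, would bring the number back down, and whether the configuration drawn in compound 3 would respond to chain length in the same way. The data shown give no measured reason for the size of these steps.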